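Phenyl Ether in Place of Benzyl Ether on a Weak Series

The source may hold more compounds than are shown below. What is called first, only, known or untested is meant among the compounds shown, and "the series" means these compounds.

Of the compounds shown here, three have been measured in an assay on HEK293 cells for inhibition of sodium channel protein type 3 subunit alpha (Homo sapiens), read by electrophysiology, with a stated time of 3.5 min; a higher number here means a weaker inhibitor, a lower number a stronger inhibitor. Compound 1 `NC(=O)[C@@H]1CC[C@H](c2cccc(OCc3ccccc3)c2)N1` carries a benzyl group on an oxygen on an aromatic ring. In this assay compound 1 gives > 100000 nM, which is a limit of the assay and not a number. Compound 2 `C[C@H](NC1CCOc2cc(OCc3ccccc3F)ccc21)C(N)=O` is built on a different core. In this assay compound 2 gives > 79400 nM, again a limit rather than a number. Compound 3 `NC(=O)CN1CCCc2cc(OCc3ccccc3F)ccc2C1` has yet another core. In this assay compound 3 gives > 79400 nM, once more a limit. Within the data shown here, compound 1 therefore stands at the limit of > 100000 nM in this assay, at which 1 of the 3 values shown sits, while the other two sit at the limit of > 79400 nM in this assay, at which 2 of the 3 values shown sit; none of the three shows measurable inhibition, and no step between measured compounds can be sized.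

Compound 4 `NC(=O)[C@@H]1CC[C@H](c2cccc(Oc3ccccc3)c2)N1` differs from compound 1 in one place: phenyl in place of benzyl on an oxygen on an aromatic ring. With every shown value at a limit, there is no measured step on which to rest a direction, and compound 4 is expected to remain at or near the limit, so the step of a number no higher from compound 1 to compound 4 (the limit leaves the size open) is expected to be small, within the scatter, in either direction. The estimate for compound 4 in this assay is 100000 nM, between 30000 nM and 300000 nM, and most likely reported only as a limit.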

Compound 4, half-maximal inhibitory concentration: > 100000 nM
Compound 4 was reported as a limit (the forecaster's own chance of this, stated with the estimate: 85%); the middle value sits exactly at the limit.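

In this assay compound 4 gives > 100000 nM, a limit of the assay and not a number. Compound 1 also stands at a limit, so the step between these two compounds cannot be read. The compounds shown leave open whether phenyl in place of benzyl on an oxygen on an aromatic ring changes inhibition at all.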